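Swapping a cyanobenzyl for a methylbenzyloxy on the core

The source may hold more compounds than are shown below. What is called first, only, known or untested is meant among the compounds shown, and "the series" means these compounds.

Measured so far:
- compound 1, `Cc1cccc(Cc2nc3cc(O[C@H]4CC[C@@H](C(=O)O)CC4)ccc3o2)c1`: 39 nM
- compound 2, `Cc1cccc(Cc2c(C(N)=O)c3cc(O[C@H]4CC[C@@H](C(=O)O)CC4)ccc3n2C)c1`: 600 nM
- compound 3, `Cn1c(Cc2cccc(C#N)c2)nc2cc(O[C@H]3CC[C@@H](C(=O)O)CC3)ccc21`: 51000 nM

All three were tested in an assay on isolated protein for inhibition of Long-chain-fatty-acid--CoA ligase 1 (Homo sapiens), read by mass spectrometry, with a stated time of 90 min, in the presence of a further agent that is not named here; a lower number here means a stronger inhibitor, a higher number a weaker inhibitor. Compound 1 gives 39 nM and compound 2 gives 600 nM, both clearly stronger than compound 3, which gives 51000 nM, the highest number of the three and well beyond the scatter from either of the others.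

Compound 4, `Cc1cccc(COc2nc3cc(O[C@H]4CC[C@@H](C(=O)O)CC4)ccc3n2C)c1`, has not been measured. It differs from compound 3 in one place: (3-methylbenzyl)oxy in place of 3-cyanobenzyl on an aromatic carbon. The nitrile-bearing benzyl group is thus replaced by a methyl-bearing benzyl group joined through an oxygen, while the rest of the shared core, including the methyl on the ring nitrogen and the acid-bearing cyclohexyl ether, stays the same.

Among the measured compounds shown here, no measured pair in this set isolates exactly this change, so the expectation rests on a comparison of the whole compounds. Compound 1 and compound 2, which both carry a methyl rather than a nitrile on the pendant benzyl ring, sit far below compound 3. On that basis a clear drop toward stronger inhibition is expected, though the added oxygen linker and the differing core leave the size uncertain. Compound 4 is estimated at 3000 nM, within a range of 300 nM to 30000 nM, an expected step of a 17-fold lower number from compound 3 to compound 4 (1.23 log units; beyond the scatter).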

Compound 4, half-maximal inhibitory concentration: 17000 nM
For compound 4 the middle estimate is 5.7-fold (0.75 log units) below the measured one, within the range that was stated.
By their numbers in this assay, from the lowest: compound 1; then compound 2; then compound 4; then compound 3.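

In this assay, among the compounds shown here, the change on this aromatic carbon, between two ring nitrogen atoms, gives a 3.0-fold lower number from compound 3 to compound 4 (0.48 log units; beyond the scatter), a modest step and the only comparison here in which two compounds differ in one place. It shows that this position responds to the exchange of 3-cyanobenzyl for (3-methylbenzyl)oxy, even though the two groups match in heavy-atom count, in their six-membered aromatic ring and in their hydrogen-bond donors and acceptors, and neither carries a net charge. Nothing measured here explains why the number moves, and the step gives only its direction and size for this one exchange.

The exchange alters two things at once, the nitrile becoming a methyl on the benzyl ring and an oxygen entering the link to the core, so the compounds shown cannot separate the share of each. A (3-cyanobenzyl)oxy group at the same place would help to divide the step between those two changes, while an amine on the benzyl ring or a longer chain in the link would test how far this position tolerates other groups.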